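The source may report more compounds than this note shows. Statements on the series, on what has been measured and on what is new or still open speak of the compounds shown alone.

Measured compounds:
Compound 1, `CNc1cc(Oc2c(OC)cc3cc(C#N)ccc3c2OC)nc(Nc2ccc(C#N)cc2)n1`: in an ADME assay on MT4 cells (Homo sapiens) for cytotoxicity, read by MTT assay, with a stated time of 5 days (on this read-out lower numbers stand for higher toxicity in this test and higher numbers for lower toxicity in this test), compound 1 gives 239000 nM.
Compound 2, `CCC(C)Nc1cc(Oc2c(OC)cc3cc(C#N)ccc3c2OC)nc(Nc2ccc(C#N)cc2)n1`: in this assay compound 2 gives only a limit of the assay, > 125000 nM.
Compound 3, `COc1cc2cc(C#N)ccc2c(OC)c1Oc1cc(NCCCOC(C)C)nc(Nc2ccc(C#N)cc2)n1`: in this assay compound 3 gives only a limit of the assay, > 125000 nM.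

All three compounds share one core and differ only in the group on a nitrogen on an aromatic ring. Compound 3 stands at a limit, so its toxicity cannot be placed more closely than that. The steps among the measured compounds, a step that the limit leaves unreadable from compound 1 to compound 2, a step that the limit leaves unreadable from compound 1 to compound 3 and a step that the two limits leave unreadable from compound 2 to compound 3, cannot be sized because of the limit of > 125000 nM in this assay, at which 2 of the 3 values shown sit.

Compound 4, `COc1cc2cc(C#N)ccc2c(OC)c1Oc1cc(NCCCO)nc(Nc2ccc(C#N)cc2)n1`, is the next compound. The change from compound 3 is hydrogen in place of isopropyl on an oxygen on a saturated carbon. Among the measured compounds shown here, no measured step gives a readable size for any change at this position, and the change itself is small. The step from compound 3 to compound 4 is therefore expected to be none beyond the scatter, written as a step that the limit leaves unreadable from compound 3 to compound 4. Compound 4 is estimated at 150000 nM, with a range from 60000 nM to 400000 nM.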

Compound 4, half-maximal cytotoxic concentration: 23500 nM
Beside the measured number, compound 4's estimate is 6.4-fold (0.81 log units) above it; the measured number lies below the stated range.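

Compound 4 gives the first readable size for a change at this position: in this assay, hydrogen in place of isopropyl on the oxygen gives an at least 5.3-fold lower number from compound 3 to compound 4 (0.72 log units; beyond the scatter), which on this read-out means higher toxicity in this test. Compared with the sec-butyl group, the 3-hydroxypropyl group gives an at least 5.3-fold lower number from compound 2 to compound 4 (0.72 log units; beyond the scatter), and the one comparison between two exact numbers gives a 10-fold lower number from compound 1 to compound 4 (1.01 log units; beyond the scatter). The steps among compound 1, compound 2 and compound 3 still cannot be read, and the first two steps given here set only a minimum size, because of the assay limit: the limit of > 125000 nM in this assay, at which 2 of the 4 values shown sit.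

Compound 4 is the only compound shown with a hydroxy group, so this single change establishes no pattern. As far as these compounds go, it remains open how a methoxy group, an amine or a carboxylic acid at the end of the chain, or a longer chain ending in hydroxy, would compare.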